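The source may report more compounds than this note shows. Statements on the series, on what has been measured and on what is new or still open speak of the compounds shown alone.

Measured compounds in this series:

Compound 1 `Cc1nc(N)c2c(-c3ccccc3)cn([C@@H]3O[C@H](CO)[C@@H](O)[C@H]3O)c2n1`; compound 2 `Cc1nc(N)c2c(-c3cccs3)cn([C@@H]3O[C@H](CO)[C@@H](O)[C@H]3O)c2n1`; compound 3 `COc1ncnc2c1c(-c1cccs1)cn2[C@@H]1O[C@H](CO)[C@@H](O)[C@H]1O`.

In a functional assay on HepG2 cells (Homo sapiens) for antiproliferative activity, read by XTT assay, with a stated time of 72 h (on this read-out lower numbers stand for stronger inhibition and higher numbers for weaker inhibition), compound 1 gives > 20000 nM, which is a limit of the assay and not a number. In this assay compound 2 likewise gives > 20000 nM, again a limit. Compound 3 is the only one of the three for which this assay returns a number: compound 3 gives 13900 nM.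

The change phenyl in place of thiophen-2-yl on an aromatic carbon connects compound 2 to compound 1, and the step it made is a step that the two limits leave unreadable from compound 2 to compound 1; both values sit at the limit of > 20000 nM in this assay, at which 2 of the 3 values shown sit, so its size cannot be read. Compound 4 `COc1ncnc2c1c(-c1ccccc1)cn2[C@@H]1O[C@H](CO)[C@@H](O)[C@H]1O` carries the same change relative to compound 3, namely (phenyl in place of thiophen-2-yl on an aromatic carbon). The difference between the core of compound 2 and the core of compound 3 is not broken down here.

Since the measured step gives no readable size, the expected step from compound 3 to compound 4 in this assay, a 1.3-fold higher number from compound 3 to compound 4 (0.11 log units; within the scatter), rests only on compound 3 at 13900 nM. It remains possible that compound 4 falls outside what the assay can report. Compound 4 is therefore estimated at 18000 nM, with a range from 7000 nM to 45000 nM.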

Compound 4, half-maximal inhibitory concentration: > 20000 nM
Compound 4: only a limit was reported; the forecaster's own chance of this, stated with the estimate: 40%; middle value at least 1.1-fold (0.04 log units) from the limit.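

In this assay compound 4 gives > 20000 nM, which is a limit of the assay and not a number. As far as these compounds go, on the core of compound 3, phenyl in place of thiophen-2-yl on an aromatic carbon gives an at least 1.4-fold higher number from compound 3 to compound 4 (0.15 log units; that floor lies within the scatter), so the change has a direction on this core, but the true size stays unknown and could be small or large. The same change on the core of compound 2 cannot be read, so the series does not show whether its effect carries from one core to the other, and the readable result rests on a single number and a limit: the limit of > 20000 nM in this assay, at which 3 of the 4 values shown sit.

The compounds shown leave open whether any group on this aromatic carbon would give a clearly readable value in this assay on either core. A furan-2-yl ring, or a phenyl ring carrying a dimethylamino group or a carboxylic acid, would be among the groups still to be placed there.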